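This account rests on a few compounds, and the source may have more. Where it says the series, first, only, none or still open, it means among the compounds named here.

Measured in a functional assay on RXF 393 cells (Homo sapiens) for cytotoxicity, read by sulforhodamine B assay, with a stated time of 48 h, tested at 100 uM; on this read-out lower numbers stand for a stronger effect and higher numbers for a weaker effect at the one concentration tested:
compound 1 `COc1cc(-c2cc(/C=C/C(=O)c3ccc(N)cc3)[nH]n2)cc(OC)c1OC` gives -86%
compound 2 `COc1ccc(-c2cc(/C=C/C(=O)c3ccc(N)cc3)[nH]n2)cc1OC` gives -95%
compound 3 `COc1cc(C(=O)/C=C/c2cc(-c3cc(OC)c(OC)c(OC)c3)n[nH]2)cc(OC)c1OC` gives -98%

Compound 1 and compound 2 share one core; the change between them is hydrogen in place of methoxy on an aromatic carbon. In this assay that step is a number 9 percentage points lower from compound 1 to compound 2 (within the scatter). Compound 3 is built on a different core, and the difference between the two cores is not broken down here. Compound 2 and compound 3 give numbers within the scatter of each other, while compound 1 lies beyond the scatter of compound 3.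

Compound 4 `COc1ccc(-c2cc(/C=C/C(=O)c3cc(OC)c(OC)c(OC)c3)[nH]n2)cc1OC` has not yet been measured in this assay. It differs from compound 3 by hydrogen in place of methoxy on an aromatic carbon, the same change as between compound 1 and compound 2, at a place described in the same words. The earlier step was a number 9 percentage points lower from compound 1 to compound 2 (within the scatter). Compound 3 already gives a number close to complete loss of cell growth, -98%, so little room remains. The expected step to compound 4 is therefore a number 2 percentage points lower from compound 3 to compound 4 (within the scatter), within the scatter. The estimate for compound 4 in this assay is -100%, expected between -110% and -88%.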

Compound 4, a percentage reported as activity, at one concentration (the size of the read-out at that concentration, not a potency): -83%
Beside the measured number, compound 4's estimate is 17 percentage points below it, outside the stated range (above it).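

In this assay, hydrogen in place of methoxy on an aromatic carbon gives a number 15 percentage points higher from compound 3 to compound 4 (beyond the scatter), and this change does not carry over from one core to the other with a fixed size or direction: the same change on two cores in this assay, a number 9 percentage points lower (within the scatter) from compound 1 to compound 2 and a number 15 percentage points higher (beyond the scatter) from compound 3 to compound 4, 24 percentage points apart, beyond the scatter of two such steps

On the core of compound 3 the loss of this methoxy weakens the effect, whereas on the core of compound 1 the step stays within the scatter, so a step read on one of these cores is a poor guide to the other. Among these compounds, only two pairs stand behind this, at a single concentration on a single cell line, and they do not show which part of the cores sets the gap or whether it would persist at other concentrations.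

Open, going by these compounds, is how the same place responds to a hydroxyl or a chlorine instead of methoxy. Also open, on these data alone, is whether a third core, for instance one carrying a carboxylic acid in place of the amino group of compound 1, would follow either pair.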